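The compounds below may be only part of what the source reports. "The series", "measured", "known", "first", "only" and "open" are said of these compounds alone.

Measured so far:
- compound 1, `CCn1c(NC2CCOCC2)nc2ccsc2c1=O`: 37 ug/mL
- compound 2, `CCn1c(NC(C)C)nc2c(-c3ccnc(OC)c3)csc2c1=O`: 2.4 ug/mL

Both compounds were tested in a physicochemical assay for solubility, in phosphate buffer, at pH 6.8; a lower number here means a less soluble compound, a higher number a more soluble compound. Of the two numbers, compound 1 has the higher one, and its value of 37 ug/mL stands clearly apart from compound 2, which gives 2.4 ug/mL. The two structures differ in more than one place, so nothing is said here about what any single part contributes to that gap.

The step considered next is from compound 1 to compound 3, `CCCNc1nc2ccsc2c(=O)n1CC`, which has not yet been measured in this assay. The change is a single one: propyl in place of oxan-4-yl on a nitrogen on an aromatic ring. The shared core, the ethyl on the ring nitrogen and the position of the attached amine all stay the same; only the group on that amine nitrogen changes.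

Among the compounds with values here, no measured pair shows this exact change, so the expectation rests on the two values available and on the change itself. A downward step in this assay is expected, of modest size, somewhat beyond the usual scatter. For compound 3 the estimate is 14 ug/mL, with a likely range from 5 ug/mL to 40 ug/mL, which corresponds to an expected step of a 2.6-fold lower number from compound 1 to compound 3 (0.42 log units; beyond the scatter).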

Compound 3, solubility: 69 ug/mL
Compound 3: the middle estimate sits 4.9-fold (0.69 log units) below what was measured; the whole stated range lies below it.
By their numbers in this assay, from the lowest: compound 2; then compounds 1 and 3 (each within the scatter of the next).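

Within the data shown here, with propyl in place of oxan-4-yl on a nitrogen on an aromatic ring, this assay gives the first direct reading at this position: a 1.9-fold higher number from compound 1 to compound 3 (0.27 log units; within the scatter). This step lies within the usual scatter of repeated measurements, so the two compounds cannot be told apart here, even though the group that leaves holds a ring and a hydrogen-bond acceptor and the group that enters holds neither. At this position the ring and its oxygen can therefore be exchanged for a propyl chain with no measurable difference in this read-out, which compound 2 could not show since it differs from compound 1 in more than one place, and nothing available gives a reason for the result.

Going by these compounds, only these two groups can be compared on this nitrogen, so it remains open whether an amine-bearing group such as piperidin-4-yl, a carboxylic acid or a longer chain such as hexyl would give a step beyond the scatter. Also open, on these data alone, is whether the same replacement would stay within the scatter in a compound that carries a further ring on the core, as compound 2 does.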